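The source may report more compounds than this note shows. Statements on the series, on what has been measured and on what is new or still open speak of the compounds shown alone.

Measured in an ADME assay on J774 cells (Mus musculus) for cytotoxicity; a lower number here means that less compound is needed, a higher number that more compound is needed for the effect:
- compound 1 `CCCCCCC/C=C/c1c(C)[nH]c2ccccc2c1=O`: 28000 nM
- compound 2 `C=C(CCCCCCC)c1c(C)[nH]c2ccccc2c1=O`: 89100 nM
- compound 3 `COc1ccc2[nH]c(C)c(Br)c(=O)c2c1`: > 37300 nM (a limit, not a number)

Compound 3 has no exact number in this assay, only the limit > 37300 nM. Compound 4 `Cc1[nH]c2ccc(F)cc2c(=O)c1Br` carries fluoro in place of methoxy on an aromatic carbon. Among the compounds with values here, no measured pair of compounds shows what such a change does, so no step beyond the scatter is expected, in either direction. The expected change is a step that the limit leaves unreadable from compound 3 to compound 4, a step within the scatter. For compound 4 the estimated value is 45000 nM, with an expected range from 22000 nM to 95000 nM.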

Compound 4, half-maximal effective concentration in the J774 assay: > 39100 nM
Compound 4: no number, only a limit; the forecaster's own chance of this, stated with the estimate: 55%; the middle value lies beyond the limit too.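

In the J774 assay, compound 3 gives > 37300 nM, which is a limit, not a number. In the J774 assay, compound 4 gives > 39100 nM, which is also a limit, not a number. No step can be read between these two limits. In a physicochemical assay for lipophilicity, at pH 7.4 (on this read-out lower numbers stand for lower lipophilicity and higher numbers for higher lipophilicity), compound 3 gives 1.62 and compound 4 gives 1.61. In the physicochemical assay, the step is a number 0.01 log units lower from compound 3 to compound 4 (within the scatter). The compounds shown leave open what fluoro in place of methoxy on an aromatic carbon does in the J774 assay.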